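Ether-tail variants of one core: cytotoxicity notes

The compounds below may be only part of what the source reports. "The series", "measured", "known", "first", "only" and "open" are said of these compounds alone.

Measured compounds:
compound 1 `COc1ccc(CCOc2ccc(-c3c(C)nc(C)c([C@H](OC(C)(C)C)C(=O)O)c3N3CCC(C)(C)CC3)cc2)cc1` — >= 33500 nM
compound 2 `Cc1nc(C)c([C@H](OC(C)(C)C)C(=O)O)c(N2CCC(C)(C)CC2)c1-c1ccc(OCCc2ccc(C#N)cc2)cc1` — >= 33500 nM
compound 3 `Cc1nc(C)c([C@H](OC(C)(C)C)C(=O)O)c(N2CCC(C)(C)CC2)c1-c1ccc(OCCc2cc(F)ccc2F)cc1` — >= 33500 nM

In a toxicity assay on MT2 cells (Homo sapiens) for cytotoxicity, read by XTT assay, with a stated time of 4 days (a lower number here means that less compound is tolerated, a higher number that more compound is tolerated), compound 1 gives >= 33500 nM, which is a limit of the assay rather than a number. Compound 2 gives >= 33500 nM, again only a limit. Compound 3 gives >= 33500 nM, likewise a limit. Among the measured compounds shown here, compound 3 therefore stands where the whole series stands: every value so far sits at the limit of >= 33500 nM in this assay, at which 3 of the 3 values shown sit, and no compound can be told apart from another on these readings.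

The measured steps reflect this. From methoxy to cyano on the aromatic carbon, a step that the two limits leave unreadable from compound 1 to compound 2. At the chain position, a step that the two limits leave unreadable from compound 1 to compound 3 and a step that the two limits leave unreadable from compound 2 to compound 3. Three changes of the tail aryl group, none of them readable.

Compound 4 `Cc1nc(C)c([C@H](OC(C)(C)C)C(=O)O)c(N2CCC(C)(C)CC2)c1-c1ccc(OCCc2ccncc2)cc1` changes the same chain position once more: pyridin-4-yl in place of 2,5-difluorophenyl on a saturated chain carbon, two bonds along the chain from an oxygen on an aromatic ring. For the measured compounds named here, the steps that bear on it are the two tail exchanges already made at that position, both unreadable within the limit. No step beyond the scatter is therefore expected from compound 3 to compound 4; the expected step is a number no higher from compound 3 to compound 4 (the limit leaves the size open). Compound 4 is estimated at 33500 nM, with a range of 15000 nM to 100000 nM, most probably reported again as a limit.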

Compound 4, half-maximal cytotoxic concentration: >= 25000 nM
Compound 4: only a limit was reported; the forecaster's own chance of this, stated with the estimate: 85%; the middle value is on the limit's open side.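

In this assay compound 4 gives >= 25000 nM, which is a limit of the assay and not a number. No step can be read from compound 4 to compound 1, compound 2 or compound 3, as all four readings are limits. The compounds shown leave open where the half-maximal cytotoxic concentration of any of the four actually lies.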